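Replacing benzyloxy with propoxy on the shared core

The compounds below may be only part of what the source reports. "The series", "measured", "known", "first", "only" and "open" are said of these compounds alone.

Compound 2 `O=c1cc(-c2ccccc2)oc2cc(O)c(OCc3ccccc3)c(O)c12` is the reference point. In a functional assay on KB cells (Homo sapiens) for inhibition, with a stated time of 72 h (a higher number here means a weaker inhibitor, a lower number a stronger inhibitor), compound 2 gives 4300 nM, the lowest of the two numbers in hand. Compound 1 `CC(=O)Oc1c(O)cc2oc(-c3ccccc3)cc(=O)c2c1O` gives 10500 nM in this assay; benzyl in place of acetyl on an oxygen on an aromatic ring produces a 2.4-fold lower number from compound 1 to compound 2 (0.39 log units; beyond the scatter). Compound 3 `O=c1cc(-c2ccccc2)oc2cc(O)c(OCc3ccccc3)c(OCc3ccccc3)c12` reaches only a limit of this assay, > 100000 nM. Compound 3 thus sits at the limit of > 100000 nM in this assay, at which 1 of the 3 values shown sits. Benzyl in place of hydrogen on an oxygen on an aromatic ring produces an at least 23-fold higher number from compound 2 to compound 3 (1.36 log units; beyond the scatter).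

Compound 4 `CCCOc1c(O)cc2oc(-c3ccccc3)cc(=O)c2c1O` differs from compound 2 by ethyl in place of phenyl on a saturated chain carbon bound to an oxygen on an aromatic ring. Neither measured step carries this exact change. The step between compound 1 and compound 2 varied the group on the same oxygen and was modest; the step from compound 2 to compound 3 added a group to an oxygen that had carried hydrogen and was large, but compound 4 keeps a substituent on the oxygen in question. Exchanging phenyl for ethyl is therefore expected to move the number little, and the estimated step is a 1.5-fold higher number from compound 2 to compound 4 (0.18 log units; within the scatter), in the direction of a slightly higher number. Compound 4 is expected to give 6500 nM in this assay, with a range of 2500 nM to 17000 nM.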

Compound 4, half-maximal inhibitory concentration: 58900 nM
The estimate for compound 4 lay 9.1-fold (0.96 log units) below the measured number; measured number above the stated range.
By their numbers in this assay, from the lowest: compound 2; then compound 1; then compound 4. At a limit, above all of these: compound 3.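

The phenyl of the benzyloxy group carries weight at this oxygen: in this assay, benzyloxy to propoxy, a change confined to the far end of the substituent, gives a 14-fold higher number from compound 2 to compound 4 (1.14 log units; beyond the scatter), so keeping a substituent on the oxygen does not by itself hold the number near that of the benzyl ether. The saturated chain also does not match acetyl on the same oxygen, with propyl in place of acetyl giving a 5.6-fold higher number from compound 1 to compound 4 (0.75 log units; beyond the scatter), so among these three groups benzyl gives the lowest number and propyl the highest, and the oxygen's group cannot be treated as interchangeable. Nothing measured here accounts for the size of either step.

Still open, as far as these compounds go, is whether the aromatic ring itself is what matters or whether a longer chain such as hexyl, or a cyclohexylmethyl group that keeps a ring without aromaticity, would bring the number back toward that of compound 2. Also open, from the compounds shown here alone, is how a benzyl carrying a methoxy group, or a pyridylmethyl group, would read at this oxygen on the shared core.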